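From methoxy to hydroxy at compound 3

This account rests on a few compounds, and the source may have more. Where it says the series, first, only, none or still open, it means among the compounds named here.

Of the compounds shown here, three have numbers so far in a physicochemical assay, read by spectrophotometry, with a stated time of 30 min; a lower number here means a stronger inhibitor, a higher number a weaker inhibitor. Compound 1 `O=C(CCc1nc2ccccc2c(=O)[nH]1)N/N=C/c1ccc(O)c(O)c1` gives 113000000 nM. Compound 2 `O=C(CCc1nc2ccccc2c(=O)[nH]1)N/N=C/c1ccc([N+](=O)[O-])cc1` gives 328000000 nM. Compound 3 `COc1cc(/C=N/NC(=O)CCCc2nc3ccccc3c(=O)[nH]2)ccc1O` gives 236000000 nM. This places compound 3 within the scatter of compound 2, and both sit at the high end of the three numbers. The number of compound 1 is lower than that of compound 3, and the gap lies beyond the scatter.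

Compound 4 `O=C(CCCc1nc2ccccc2c(=O)[nH]1)N/N=C/c1ccc(O)c(O)c1` differs from compound 3 by a single change (hydrogen in place of methyl on an oxygen on an aromatic ring). It is hydrogen in place of methyl on an oxygen on an aromatic ring, so 4-hydroxy-3-methoxyphenyl becomes 3,4-dihydroxyphenyl.

For the measured compounds named here, no measured step isolates this change. The nearest evidence is a 2.9-fold higher number from compound 1 to compound 2 (0.46 log units; beyond the scatter), a modest step in which 4-nitrophenyl replaces 3,4-dihydroxyphenyl. It is only indirect support, since the group leaving there is not the one changing here. Going by the values given here, compound 4 carries the same 3,4-dihydroxyphenyl as compound 1 but on a different chain, and compound 1 gives the lowest number so far at 113000000 nM. A small move towards a lower number in this assay is therefore expected, probably not beyond the scatter. The estimated step is a 1.7-fold lower number from compound 3 to compound 4 (0.23 log units; within the scatter). For compound 4 the estimated value is 140000000 nM, with an expected range of 70000000 nM to 270000000 nM.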

Compound 4, half-maximal inhibitory concentration: 95000000 nM
Estimate against measurement, compound 4: 1.5-fold (0.17 log units) above, and the stated range covers the measured number.
By their numbers in this assay, from the lowest: compounds 4 and 1 (each within the scatter of the next); then compounds 3 and 2 (each within the scatter of the next).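

In this assay, for the compounds shown here, the change of 4-hydroxy-3-methoxyphenyl to 3,4-dihydroxyphenyl gives a 2.5-fold lower number from compound 3 to compound 4 (0.40 log units; beyond the scatter) and is the first direct reading of this change: the loss of one methyl from an oxygen on an aromatic ring moves the number beyond the scatter. On their different chains, compound 4 at 95000000 nM and compound 1 at 113000000 nM lie within the scatter of each other, so among the compounds shown the 3,4-dihydroxyphenyl group stands at the low end of the numbers on both chains. Nothing given here accounts for the step, and it remains an observation on one pair.

The compounds shown leave open how an ethoxy group, an amine or a carboxylic acid would read at this oxygen-bearing place on the aromatic ring, and so whether the methyl itself or any group on that oxygen sets the number. They also leave open whether methoxy to hydroxy gives a step of like size on the chain of compound 1, and how 3,4-dihydroxyphenyl would read on a longer chain.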